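The compounds below may be only part of what the source reports. "The series", "measured", "known", "first", "only" and "open" are said of these compounds alone.

In an ADME assay on PC-12 cells (Rattus norvegicus) for cytotoxicity, read by WST assay, with a stated time of 24 h (on this read-out lower numbers stand for higher toxicity in this test and higher numbers for lower toxicity in this test), compound 1 (`O=C(/C=C/c1cccc(O)c1)CC(=O)/C=C/c1cccc(O)c1O`) gives 38000 nM and compound 2 (`O=C(/C=C/c1ccccc1O)CC(=O)/C=C/c1cc(O)ccc1O`) gives 38000 nM, so compound 2 stands level with compound 1. Compound 3 (`O=C(/C=C/c1cccc(O)c1)CC(=O)/C=C/c1cc(O)ccc1O`) awaits measurement. It carries 3-hydroxyphenyl in place of the 2-hydroxyphenyl of compound 2, on a double-bonded chain carbon bound to a double-bonded chain carbon: 3-hydroxyphenyl in place of 2-hydroxyphenyl on a double-bonded chain carbon bound to a double-bonded chain carbon. No measured step sizes this change, but compound 1, at 38000 nM, also carries 3-hydroxyphenyl, so no change beyond the scatter is expected in this assay. The expected step is no change at the digits printed from compound 2 to compound 3 (within the scatter). For compound 3 the estimated value is 38000 nM, with an expected range of 17000 nM to 80000 nM.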

Compound 3, half-maximal cytotoxic concentration: 15000 nM
The estimate for compound 3 lay 2.5-fold (0.40 log units) above the measured number, and the stated range ends above it.
By their numbers in this assay, from the lowest: compound 3; then compounds 1 and 2 (each within the scatter of the next).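

In this assay, 3-hydroxyphenyl in place of 2-hydroxyphenyl on a double-bonded chain carbon bound to a double-bonded chain carbon gives a 2.5-fold lower number from compound 2 to compound 3 (0.40 log units; beyond the scatter), so this change registers when 2,5-dihydroxyphenyl sits on the other end of the chain. With 3-hydroxyphenyl held fixed, 2,5-dihydroxyphenyl in place of 2,3-dihydroxyphenyl gives a 2.5-fold lower number from compound 1 to compound 3 (0.40 log units; beyond the scatter), the first sign that this end also moves the number. No measurement at hand explains either step. As far as these compounds go, whether a methoxy group or an amine in place of the hydroxyl would shift the number stays open, as does whether these steps hold in other cells.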